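A few compounds are considered here, and "the series" means these few. Any claim that something is new, unique, unknown or untested is made for them only; others in the source may bear on it.

Three measured compounds share one core, and a fourth, compound 4 `FC(F)(F)c1c(CN2CCC(c3ccccc3Cl)CC2)ccn2c(CC3CC3)nnc12`, has yet to be measured. In an assay on CHO cells for positive allosteric modulation of metabotropic glutamate receptor 2 (Homo sapiens), read by scintillation counting, with a stated time of 30 min (on this read-out higher numbers stand for an effect only at larger amounts of compound and lower numbers for an effect already at smaller amounts), compound 1 `FC(F)(F)c1c(CN2CCC(c3ccccc3)CC2)ccn2c(CC3CC3)nnc12` gives 21 nM. Compound 2 `CC1(c2ccccc2)CCCN(Cc2ccn3c(CC4CC4)nnc3c2C(F)(F)F)C1` gives 2.6 nM in this assay. Compound 3 `Fc1ccccc1C1CCN(Cc2ccn3c(CC4CC4)nnc3c2C(F)(F)F)CC1` gives 15 nM in this assay.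

Among these three numbers compound 3 stands second highest. Its nearest neighbour is compound 1: the step of a 1.4-fold lower number from compound 1 to compound 3 (0.15 log units; within the scatter) lies within the scatter, so the two cannot be told apart. Compound 2 is the furthest away, and its lower number lies beyond the scatter from that of compound 3.

Compound 4 differs from compound 3 in one place: chloro in place of fluoro on an aromatic carbon. Among the compounds with values here, no measured step swaps one halogen for another. Within the data shown here, the only step at this same place is the one from compound 1 to compound 3, where fluoro entered for hydrogen, and it stayed within the scatter. On that evidence the exchange of fluoro for chloro is expected to move the number little, and the step of a 1.3-fold lower number from compound 3 to compound 4 (0.10 log units; within the scatter) is estimated to stay within the scatter. Compound 4 is therefore expected to give about 12 nM in this assay, with a range from 4 nM to 40 nM.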

Compound 4, half-maximal effective concentration: 13.5 nM
The estimate for compound 4 lay 1.1-fold (0.05 log units) below the measured number, within the range that was stated.
By their numbers in this assay, from the lowest: compound 2; then compounds 4, 3 and 1 (each within the scatter of the next).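

In this assay, within the data shown here, the change from 2-fluorophenyl to 2-chlorophenyl gives the first measured exchange of one halogen for another on this aromatic carbon, ortho to a large group, and the step of a 1.1-fold lower number from compound 3 to compound 4 (0.05 log units; within the scatter) shows that this exchange leaves the number unresolved from that of the fluoro compound. Set against the unsubstituted phenyl, chloro gives the step of a 1.6-fold lower number from compound 1 to compound 4 (0.19 log units; within the scatter) and so, like fluoro before it, cannot be told apart from hydrogen here; among hydrogen, fluoro and chloro, the choice at this place therefore makes no difference that this read-out can detect. Nothing at hand bears on what lies behind this flat result.

The compounds shown carry only hydrogen, fluoro or chloro at this place, so it remains open whether a group of another kind, such as methoxy, a nitrile, an amine or a carboxylic acid, would also leave the number within the scatter or would move it clearly. Also open, from the compounds shown here alone, is whether chloro on another carbon of this phenyl ring would behave in the same way.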